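Swapping a Ring Carbon for Oxygen on the Amide

The source may hold more compounds than are shown below. What is called first, only, known or untested is meant among the compounds shown, and "the series" means these compounds.

Compound 1, `CC1CC(C(=O)N2CCc3nc(C#Cc4ccccc4)sc3C2)C1`, gives 81 nM.
Compound 2, `O=C(C1CCCCC1)N1CCc2nc(C#Cc3ccccc3)sc2C1`, gives 167 nM.
Compound 3, `O=C(C1CCCCO1)N1CCc2nc(C#Cc3ccccc3)sc2C1`, is not yet measured.

All three share one core and differ only in the group on the carbonyl carbon. Among the compounds with values here, in an assay on HEK293 cells for positive allosteric modulation of metabotropic glutamate receptor 5 (Homo sapiens), read by FLIPR, with a stated time of 1 h (on this read-out lower numbers stand for an effect already at smaller amounts and higher numbers for an effect only at larger amounts of compound), compound 2 holds the higher of the two measured numbers; the single measured step, a 2.1-fold higher number from compound 1 to compound 2 (0.31 log units; beyond the scatter), is modest. Compound 3 carries oxan-2-yl in place of cyclohexyl on a carbonyl carbon. Within the data shown here, no measured step tests this kind of exchange, and the one known step was modest, so little change beyond the scatter is expected: a 1.3-fold higher number from compound 2 to compound 3 (0.12 log units; within the scatter). Compound 3 is therefore estimated at 220 nM, with a range from 70 nM to 700 nM.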

Compound 3, half-maximal effective concentration: 320 nM
Estimate against measurement, compound 3: 1.5-fold (0.16 log units) below; the measured number falls inside the stated range.
By their numbers in this assay, from the lowest: compound 1; then compounds 2 and 3 (each within the scatter of the next).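

In this assay, putting an oxygen into the ring, so that cyclohexyl becomes oxan-2-yl with one hydrogen-bond acceptor gained and the same number of heavy atoms, gives a 1.9-fold higher number from compound 2 to compound 3 (0.28 log units; within the scatter), so this single exchange is not separated from the scatter. Measured against the 3-methylcyclobutyl group, the same oxan-2-yl group gives a clearer step, a 4.0-fold higher number from compound 1 to compound 3 (0.60 log units; beyond the scatter). No evidence is available to explain either step.

Still open, from the compounds shown here alone, is whether the oxygen's place in the ring matters, as oxan-4-yl would show. Also open, going by these compounds, is how a ring amine such as piperidin-4-yl would compare on the carbonyl carbon.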